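A nitro swap in a series read only as limits

The compounds below may be only part of what the source reports. "The series", "measured", "known", "first", "only" and "open" are said of these compounds alone.

In a functional assay on MCF7 cells (Homo sapiens) for cytotoxicity, read by sulforhodamine B assay (a lower number here means that less compound is tolerated, a higher number that more compound is tolerated), compound 1 (`CC1=CC[C@@H]([C@@](C)(O)CCCC(C)(C)NC=S)CC1`) gives > 100000 nM and this is a limit, not a number. Compound 2 (`CC1=CC[C@@H]([C@@](C)(O)CCCC(C)(C)NC(=S)N/N=C\c2ccc(C)cc2)CC1`) gives > 100000 nM and this too is a limit. Compound 3 (`COc1ccc(/C=N\NC(=S)NC(C)(C)CCC[C@](C)(O)[C@@H]2CC=C(C)CC2)cc1`) gives > 100000 nM and this is again only a limit, so its position has no exact number to start from.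

Compound 4 (`CC1=CC[C@@H]([C@@](C)(O)CCCC(C)(C)NC(=S)N/N=C\c2ccc([N+](=O)[O-])cc2)CC1`) has not yet been measured. It carries nitro in place of methoxy on an aromatic carbon, para to a large group (nitro in place of methoxy on an aromatic carbon). Going by the values given here, the only measured change on that aromatic carbon is a step that the two limits leave unreadable from compound 2 to compound 3 and it offers no size to carry forward. The whole record so far is the limit of > 100000 nM in this assay, at which 3 of the 3 values shown sit, and it shows no direction either. No change beyond the scatter is therefore expected in this assay from this swap. The expected step is a number no higher from compound 3 to compound 4 (the limit leaves the size open) with neither direction favoured. Compound 4 is estimated at 100000 nM with an expected range from 40000 nM to 200000 nM in this measurement.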

Compound 4, concentration lethal to 50% of the cells: > 100000 nM
Compound 4 ended at the assay's limit; the forecaster's own chance of this, stated with the estimate: 80%; the middle value lies on the limit itself.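

Neither the swap from compound 3 to compound 4 nor the one from compound 2 to compound 4 gives a step that can be read, and the record remains a single limit: the limit of > 100000 nM in this assay, at which 4 of the 4 values shown sit.

The compounds shown leave open where each true value lies in this assay, and whether methyl, methoxy and nitro differ there at all.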